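Benzyl for phenyl on the triazole: cytotoxicity working notes

The compounds below may be only part of what the source reports. "The series", "measured", "known", "first", "only" and "open" are said of these compounds alone.

The series is followed in an ADME assay on HEK293 cells (Homo sapiens) for cytotoxicity, read by MTT assay, with a stated time of 24 h; a lower number here means a stronger inhibitor, a higher number a weaker inhibitor. Compound 1 `O=C1NC(O)(CCn2cc(-c3ccccc3)nn2)C(OCc2ccccc2)=C1OCc1ccccc1` is the reference point here. In this assay compound 1 gives only a limit, > 100000 nM, and not a number, which is the limit of > 100000 nM in this assay, at which 1 of the 2 values shown sits. Compound 2 `COC1=C(OC)C(O)(CCn2cc(-c3ccccc3)nn2)NC1=O` is the other measured member; in this assay compound 2 gives 62000 nM. Among the compounds with values here, compound 2 differs from compound 1 in more than one place, so no single step between the two is counted; what the two values show is that both compounds lie at the high end of the concentration range covered by this assay.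

Compound 3 `O=C1NC(O)(CCn2cc(Cc3ccccc3)nn2)C(OCc2ccccc2)=C1OCc1ccccc1` has not yet been measured. It differs from compound 1 by benzyl in place of phenyl on an aromatic carbon. Within the data shown here, no measured step of this kind exists, so the expectation rests on the change alone. The step of a number no higher from compound 1 to compound 3 (the limit leaves the size open) is expected to be small, with no direction beyond the scatter. Compound 3 is estimated at 100000 nM in this assay, within 45000 nM to 250000 nM, and a limit rather than a number is the likely report.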

Compound 3, half-maximal inhibitory concentration: 86000 nM
Estimate against measurement, compound 3: 1.2-fold (0.07 log units) above, and the stated range covers the measured number.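

Within this assay, benzyl in place of phenyl on an aromatic carbon of the five-membered ring gives an at least 1.1-fold lower number from compound 1 to compound 3 (0.06 log units; that floor lies within the scatter), the only step in the series that can be read so far, and it can be read only as a floor. The true size of the step stays bounded by the reference compound, whose value is a limit and not a number: the limit of > 100000 nM in this assay, at which 1 of the 3 values shown sits. Compound 3 gives 86000 nM, a measured number that still lies at the high end of the concentration range covered, so at this position the change from 4-phenyl-1H-1,2,3-triazol-1-yl to 4-benzyl-1H-1,2,3-triazol-1-yl does not bring the core of compound 1 into the lower part of that range.

The compounds shown leave open whether a longer chain such as phenethyl, or an amine or a carboxylic acid on the aromatic ring of this group, would give a number clearly lower than that of compound 3. They also leave open whether the same change would give a step of similar size on the core of compound 2.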